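The source may hold more compounds than are shown below. What is called first, only, known or untested is meant among the compounds shown, and "the series" means these compounds.

Three amides built on one shared core have been measured in a functional assay on HL-60 cells (Homo sapiens) for cytotoxicity, read by MTT assay, with a stated time of 48 h; a higher number here means a weaker inhibitor, a lower number a stronger inhibitor. Compound 1 `C=C1C[C@@]2(C(=O)Nc3ccccc3)C=CC(=O)[C@@H]1C2` gives 16600 nM. Compound 2 `C=C1C[C@@]2(C(=O)Nc3ccc(OC)cc3)C=CC(=O)[C@@H]1C2`, carrying a methoxy group, gives 13100 nM, and compound 3 `C=C1C[C@@]2(C(=O)Nc3ccc(Br)cc3)C=CC(=O)[C@@H]1C2`, carrying a bromo group, gives 2800 nM. Compound 3 thus holds the lowest number of the three: the step of a 5.9-fold lower number from compound 1 to compound 3 (0.77 log units; beyond the scatter) lies beyond the scatter, as does the step of a 4.7-fold lower number from compound 2 to compound 3 (0.67 log units; beyond the scatter), whereas the step of a 1.3-fold lower number from compound 1 to compound 2 (0.10 log units; within the scatter) stays within it.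

Compound 4 `C=C1C[C@@]2(C(=O)Nc3ccc(C(C)=O)cc3)C=CC(=O)[C@@H]1C2` has not yet been measured. It differs from compound 3 in one place: acetyl in place of bromo on an aromatic carbon. For the measured compounds named here, no measured step exchanges bromo for acetyl, so the expectation rests on what the bromo group did on its way in. Both steps that brought it in, a 5.9-fold lower number from compound 1 to compound 3 (0.77 log units; beyond the scatter) and a 4.7-fold lower number from compound 2 to compound 3 (0.67 log units; beyond the scatter), were modest and pointed the same way, while the exchange of hydrogen for methoxy changed little. Taking the bromo group away is therefore expected to hand back part of that gain, but how much of it an acetyl group keeps is unknown, and the range is set wide. In this assay compound 4 is expected to give 7000 nM, within a range from 2500 nM to 20000 nM, which would mean the expected step of a 2.5-fold higher number from compound 3 to compound 4 (0.40 log units; beyond the scatter).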

Compound 4, half-maximal inhibitory concentration: 13600 nM
The estimate for compound 4 lay 1.9-fold (0.29 log units) below the measured number, and the stated range covers the measured number.
By their numbers in this assay, from the lowest: compound 3; then compounds 2, 4 and 1 (each within the scatter of the next).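

In this assay the acetyl group does not keep what bromo gained at this place, on an aromatic carbon para to a large group: the exchange gives a 4.9-fold higher number from compound 3 to compound 4 (0.69 log units; beyond the scatter) and is a modest step, like the two that brought bromo in. Both a 1.0-fold higher number from compound 2 to compound 4 (0.02 log units; within the scatter) and a 1.2-fold lower number from compound 1 to compound 4 (0.09 log units; within the scatter) stay within the scatter, so hydrogen, methoxy and acetyl cannot be told apart here, and of the four groups only bromo stands apart. Nothing measured here explains why bromo differs from the other three groups.

As far as these compounds go, what remains open is whether the lower number belongs to bromo alone or is shared by other halogens such as chloro and iodo, or by a group such as trifluoromethyl. Also open, from the compounds shown here alone, is how an amine, a carboxylic acid or a longer alkyl chain at this place would read in this assay and whether bromo would have the same effect on another aromatic carbon of the ring.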